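The source may report more compounds than this note shows. Statements on the series, on what has been measured and on what is new or still open speak of the compounds shown alone.

Of the compounds shown here, three have been measured. Compound 1 `COC(=O)/C=C/c1cccc(N(Cc2ccc(-c3ccc(C)cc3)cc2)C(=O)NC(C)C)c1` gives 449 nM in an assay on isolated protein with Bile acid receptor (Homo sapiens) as the target; on this read-out higher numbers stand for an effect only at larger amounts of compound and lower numbers for an effect already at smaller amounts. Compound 2 `COC(=O)/C=C/c1cccc(N(Cc2ccc(-c3ccc(N(C)C)cc3)cc2)C(=O)NC(C)C)c1` gives 162 nM in this assay. Compound 3 `COC(=O)/C=C/c1cccc(N(Cc2ccc(/C=C/C(=O)OC(C)(C)C)cc2)C(=O)c2ccco2)c1` gives 205 nM in this assay.

Among these three numbers compound 3 holds the second highest place. Its nearest neighbour is compound 2, and the gap between the two lies within the usual scatter, so the two cannot be told apart. Compound 1 gives the higher number, and that gap lies beyond the scatter.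

Compound 4 `COC(=O)/C=C/c1cccc(N(Cc2ccc(/C=C/C(=O)OC(C)(C)C)cc2)C(=O)NC(C)C)c1` is obtained from compound 3 by one change: isopropylamino in place of furan-2-yl on a carbonyl carbon. Among the compounds with values here, the only measured step, a 2.8-fold lower number from compound 1 to compound 2 (0.44 log units; beyond the scatter), concerns a group on the far end of the molecule and says nothing about the carbonyl group that changes here. Within the data shown here, compounds 1 and 2 carry the same isopropylcarbamoyl group as compound 4, yet each differs from compound 3 in two places, so no single step connects them to it. Their two values bracket the value of compound 3, one higher and one lower. On this basis no step beyond the scatter is expected, a 1.2-fold higher number from compound 3 to compound 4 (0.09 log units; within the scatter). The estimate for compound 4 in this assay is 250 nM, with a range from 80 nM to 800 nM.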

Compound 4, half-maximal effective concentration: 212 nM
Estimate against measurement, compound 4: 1.2-fold (0.07 log units) above; measured number inside the range.
By their numbers in this assay, from the lowest: compounds 2, 3 and 4 (each within the scatter of the next); then compound 1.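

In this assay, replacing the furan-2-yl on this carbonyl carbon with isopropylamino removes the ring and adds a hydrogen-bond donor, yet the result is a 1.0-fold higher number from compound 3 to compound 4 (0.01 log units; within the scatter), so the two compounds cannot be told apart and this position accepts both a five-membered aromatic ring and an open branched group. Compound 4 also allows the group on the aromatic carbon to be compared directly: 2-(tert-butoxycarbonyl)ethenyl in place of 4-(dimethylamino)phenyl gives a 1.3-fold higher number from compound 2 to compound 4 (0.12 log units; within the scatter), which stays within the scatter, whereas the same group in place of 4-methylphenyl gives a 2.1-fold lower number from compound 1 to compound 4 (0.33 log units; beyond the scatter), a modest step beyond it. Nothing available explains why the carbonyl change leaves the number in place.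

At this carbonyl carbon, only furan-2-yl and isopropylamino can be compared directly, and only with 2-(tert-butoxycarbonyl)ethenyl on the aromatic carbon, so the compounds shown leave open how a cyclohexyl ring or a diethylamino group would read there. Also open, on these data alone, is whether a carboxylic acid in place of the tert-butyl ester would keep the number in this range.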